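Ring size at the amino group: cyclobutyl to cyclopentyl

The source may report more compounds than this note shows. Statements on the series, on what has been measured and on what is new or still open speak of the compounds shown alone.

Measured compounds:
- compound 1, `CCn1c(-c2ccccc2)nc2c(NC3CCC3)ncnc21`: 1440 nM
- compound 2, `Cn1c(-c2ccc(C(=O)O)cc2)nc2c(NC3CCCC3)ncnc21`: > 30000 nM

For the measured compounds named here, in a functional assay on CHO cells for antagonist activity at adenosine receptor A2b (Homo sapiens), read by 33P incorporation, with a stated time of 20 min (on this read-out lower numbers stand for stronger inhibition and higher numbers for weaker inhibition), compound 1 gives 1440 nM, the only plain number among the values shown. Compound 2 reaches only > 30000 nM, which is a limit of the assay rather than a number, as the limit of > 30000 nM in this assay, at which 1 of the 2 values shown sits, records. Compound 2 differs from compound 1 in several places at once, so its result says nothing on its own about any single change.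

The unmeasured compound 3, `CCn1c(-c2ccccc2)nc2c(NC3CCCC3)ncnc21`, differs from compound 1 in one place only: cyclopentyl in place of cyclobutyl on a nitrogen on an aromatic ring. Going by the values given here, a change of this kind, one ring carbon more on a saturated ring at the amino nitrogen, is small, and no measured pair isolates it here.

Compound 3 is therefore expected to sit close to compound 1, with the step of a 1.0-fold higher number from compound 1 to compound 3 (0.02 log units; within the scatter) expected to stay within the usual scatter of this assay in either direction. The estimate for compound 3 is 1500 nM, with a likely range from 500 nM to 5000 nM.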

Compound 3, inhibition constant: 5790 nM
The estimate for compound 3 lay 3.9-fold (0.59 log units) below the measured number; the measured number lies above the stated range.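

Cyclopentyl in place of cyclobutyl on a nitrogen on an aromatic ring is the first change here that can be read on its own, and in this assay it gives a 4.0-fold higher number from compound 1 to compound 3 (0.60 log units; beyond the scatter) with the rest of the molecule unchanged. This position therefore responds to ring size: one more ring carbon, with no hydrogen-bond donor or acceptor entering or leaving, is enough to weaken inhibition by more than the usual scatter of repeated measurements. The compounds shown offer no measured explanation for this loss.

The two ring sizes compared here leave open whether a cyclohexyl ring would raise the number further or a cyclopropyl ring would lower it, and a single step sets no rule for other substituents on the core. They also leave open how this position would respond to a group of a different kind, such as an open propyl chain or a saturated ring carrying a hydroxyl group or an amine.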